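This account rests on a few compounds, and the source may have more. Where it says the series, first, only, none or still open, it means among the compounds named here.

Compound 1, `Oc1cc(C(F)(F)F)nc(SCCCCc2ccccc2)n1`, and compound 2, `Nc1cc(N)nc(SCCCCc2ccccc2)n1`, share one core with a chain ending in a phenyl group and differ only in the two small groups on the ring. In a functional assay on HEK293 cells for agonist activity at G-protein coupled receptor 84 (Homo sapiens), read by calcium flux (on this read-out higher numbers stand for an effect only at larger amounts of compound and lower numbers for an effect already at smaller amounts), compound 1 returns only a limit of > 100000 nM, not a number. Compound 2 likewise reaches only a limit of > 100000 nM in this assay. Compound 2 thus stands at the edge of what the assay can report, as does every value shown: the limit of > 100000 nM in this assay, at which 2 of the 2 values shown sit. Compound 3, `Nc1cc(O)nc(SCCCCc2ccccc2)n1`, is not yet measured. It differs from compound 2 by hydroxy in place of amino on an aromatic carbon. Among the measured compounds shown here, with both neighbours at the limit, no measured step gives a direction, and the change from compound 2 to compound 3 is expected to bring nothing beyond the scatter. The expected step is a number no higher from compound 2 to compound 3 (the limit leaves the size open). Compound 3 is therefore estimated at 100000 nM in this assay, within a range from 30000 nM to 300000 nM, and most likely as a limit rather than a number.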

Compound 3, half-maximal effective concentration: > 100000 nM
Compound 3 gave a limit, no number (the forecaster's own chance of this, stated with the estimate: 80%); the middle value lies on the limit itself.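

Neither the step from compound 2 to compound 3 nor the one from compound 1 to compound 3 can be read in this assay: the limit of > 100000 nM in this assay, at which 3 of the 3 values shown sit.

The compounds shown leave open whether any change of the small groups on the shared core would give a number rather than a limit.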